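The source may report more compounds than this note shows. Statements on the series, on what has been measured and on what is new or still open speak of the compounds shown alone.

In a functional assay on Lewis lung carcinoma cells for cytotoxicity against Lewis lung carcinoma cell line (Mus musculus), read by MTT assay, with a stated time of 72 h (a lower number here means a stronger inhibitor, a higher number a weaker inhibitor), compound 1 `O=C1/C(=C/c2ccccc2)COC/C1=C\c1ccccc1F` gives 16000 nM and compound 2 `O=C1/C(=C/c2ccccc2F)COC/C1=C\c1ccccc1C(=O)O` gives 17200 nM as its reading, so the two lie within the scatter of each other. Compound 3 `COc1ccccc1/C=C1\COC/C(=C\c2ccccc2F)C1=O` differs from compound 2 by methoxy in place of carboxy on an aromatic carbon. Among the measured compounds shown here, the one measured step that bears on this change is carboxy in place of hydrogen on an aromatic carbon, a 1.1-fold higher number from compound 1 to compound 2 (0.03 log units; within the scatter) in all. No step beyond the scatter is therefore expected in this assay for this exchange. The estimated step is a 1.1-fold lower number from compound 2 to compound 3 (0.06 log units; within the scatter) as the expected outcome. Compound 3 is expected at 15000 nM, within an estimated range of 6000 nM to 38000 nM when measured.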

Compound 3, half-maximal inhibitory concentration: 15400 nM
Compound 3: middle estimate off by 1.0-fold (0.01 log units), on the low side; measured number inside the range.
By their numbers in this assay, from the lowest: compounds 3, 1 and 2 (each within the scatter of the next).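

With methoxy on this aromatic carbon, this assay gives a 1.1-fold lower number from compound 2 to compound 3 (0.05 log units; within the scatter) and a 1.0-fold lower number from compound 1 to compound 3 (0.02 log units; within the scatter). The earlier compounds shown here compared only hydrogen and carboxy here; hydrogen, carboxy and methoxy now all lie within the scatter of one another, so none of these three groups sets itself apart at this position in this assay. Nothing measured here gives a reason for this result. The compounds shown leave open whether an amine, a chlorine atom or a longer alkoxy chain at this place would give a step beyond the scatter.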